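Replacing cyclopropylamino by pyridinylpiperazinyl on a chloromethylphenyl urea

This account rests on a few compounds, and the source may have more. Where it says the series, first, only, none or still open, it means among the compounds named here.

Measured compounds:
- compound 1, `O=C(Nc1ccccc1)Nc1nc(NC2CC2)cc(Sc2c[nH]c3ccccc23)n1`: > 50000 nM
- compound 2, `O=C(Nc1ccccc1)Nc1nc(Sc2c[nH]c3ccccc23)cc(N2CCN(c3ccccn3)CC2)n1`: 30300 nM
- compound 3, `Cc1cc(Cl)ccc1NC(=O)Nc1nc(NC2CC2)cc(Sc2c[nH]c3ccccc23)n1`: 31500 nM

In a functional assay on A549 cells (Homo sapiens) for inhibition, with a stated time of 72 h (on this read-out lower numbers stand for stronger inhibition and higher numbers for weaker inhibition), compound 1 gives > 50000 nM, which is a limit of the assay and not a number (the limit of > 50000 nM in this assay, at which 1 of the 3 values shown sits). In this assay compound 2 gives 30300 nM and compound 3 gives 31500 nM; these two values lie within the scatter of each other. The change from compound 1 to compound 2 is 4-(pyridin-2-yl)piperazin-1-yl in place of cyclopropylamino on an aromatic carbon, and the step it made was an at least 1.6-fold lower number from compound 1 to compound 2 (0.21 log units; that floor lies within the scatter). The change from compound 1 to compound 3 is 4-chloro-2-methylphenyl in place of phenyl on an amide-type nitrogen, with the step of an at least 1.5-fold lower number from compound 1 to compound 3 (0.20 log units; that floor lies within the scatter).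

Compound 4, `Cc1cc(Cl)ccc1NC(=O)Nc1nc(Sc2c[nH]c3ccccc23)cc(N2CCN(c3ccccn3)CC2)n1`, has not yet been measured. It differs from compound 3 by 4-(pyridin-2-yl)piperazin-1-yl in place of cyclopropylamino on an aromatic carbon. This is the same kind of change as that from compound 1 to compound 2; the place differs in that the group there was meta to a (phenylcarbamoyl)amino group, whereas here it is meta to a large group, the cores differing as told by the change from compound 1 to compound 3. Since the earlier step started from a limit, its floor only bounds the effect, and the step from compound 3 to compound 4 is expected to be of a similar modest size, a 1.6-fold lower number from compound 3 to compound 4 (0.20 log units; within the scatter). Compound 4 is therefore estimated at 20000 nM, with a range from 8000 nM to 50000 nM.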

Compound 4, half-maximal inhibitory concentration: > 50000 nM
Compound 4: no number, only a limit; the forecaster's own chance of this, stated with the estimate: 15%; middle value at least 2.5-fold (0.39 log units) away from the limit.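

In this assay compound 4 gives > 50000 nM, which is a limit of the assay and not a number, and it shares that limit with one other compound: the limit of > 50000 nM in this assay, at which 2 of the 4 values shown sit. Putting 4-(pyridin-2-yl)piperazin-1-yl in place of cyclopropylamino on the core of compound 3 gives an at least 1.5-fold higher number from compound 3 to compound 4 (0.20 log units; that floor lies within the scatter), so the data do not show the lower number that the same change seemed to give on the other core, yet they do not establish that the change acts differently on the two cores: the same change on two cores in this assay, an at least 1.6-fold lower number (0.21 log units; that floor lies within the scatter) from compound 1 to compound 2 and an at least 1.5-fold higher number (0.20 log units; that floor lies within the scatter) from compound 3 to compound 4; the limit leaves it open whether they differ. The change of phenyl to 4-chloro-2-methylphenyl on the urea nitrogen reads the same way, with an at least 1.6-fold higher number from compound 2 to compound 4 (0.21 log units; that floor lies within the scatter), and this pair likewise neither shows that the change carries from one core to the other nor shows that it fails to: the same change on two cores in this assay, an at least 1.5-fold lower number (0.20 log units; that floor lies within the scatter) from compound 1 to compound 3 and an at least 1.6-fold higher number (0.21 log units; that floor lies within the scatter) from compound 2 to compound 4; the limit leaves it open whether they differ.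

As far as these compounds go, with two of the four compounds at the limit, the true size of every step stays unknown, and so does whether the two changes combine in any regular way. From the compounds shown here alone, it also remains open whether a morpholine or an unsubstituted piperazine in place of cyclopropylamino, or a methoxy or fluoro group on the phenyl ring of the urea, would give numbers clearly apart from this limit.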